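Cyclohexyl in place of methyl on a carbonyl carbon

The compounds below may be only part of what the source reports. "The series", "measured", "known", "first", "only" and "open" are said of these compounds alone.

Measured in a toxicity assay on THP-1 cells (Homo sapiens) for inhibition; on this read-out lower numbers stand for higher toxicity in this test and higher numbers for lower toxicity in this test:
- compound 1 `COc1ccc(-c2cnc(NC(=O)c3cnco3)n2C)cc1`: > 100000 nM, a limit
- compound 2 `COc1ccc(-c2cnc(NC(C)=O)n2C)cc1`: > 100000 nM, a limit

In this assay compound 2 has no numerical value and stands at the limit of > 100000 nM. Compound 3 `COc1ccc(-c2cnc(NC(=O)C3CCCCC3)n2C)cc1` has not yet been measured. It carries cyclohexyl in place of methyl on a carbonyl carbon.

For the measured compounds named here, the one measured step changes the group at this same carbonyl carbon: a step that the two limits leave unreadable from compound 1 to compound 2. It therefore bears on the change, but it offers no size to carry over. The two measured compounds share one limit: the limit of > 100000 nM in this assay, at which 2 of the 2 values shown sit. Compound 1, with 1,3-oxazol-5-yl on that carbon, also stands at the limit of > 100000 nM.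

Going by the values given here, no step of known size or direction can therefore be drawn for this assay. The most likely outcome is another result at the limit, although a number somewhat under it remains possible. The expected step is a number no higher from compound 2 to compound 3 (the limit leaves the size open). Compound 3 is estimated at 100000 nM, with an expected range of 40000 nM to 250000 nM.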

Compound 3, half-maximal cytotoxic concentration: > 100000 nM
Compound 3 was reported as a limit (the forecaster's own chance of this, stated with the estimate: 75%); the middle value sits exactly at the limit.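

In this assay compound 3, like compound 1 and compound 2, is reported only as a limit, so none of the steps among the three can be read: the limit of > 100000 nM in this assay, at which 3 of the 3 values shown sit.

The compounds shown leave open whether any group on this carbonyl carbon would give a value under that limit, and how large such a step would be.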